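Swapping a propyl for a 4-fluorophenyl on the imidazole nitrogen

This account rests on a few compounds, and the source may have more. Where it says the series, first, only, none or still open, it means among the compounds named here.

Compound 1 `CCCn1ccnc1-c1cc(OC)c(OC)c(OC)c1`: > 100000 nM
Compound 2 `COc1cc(-c2nccn2S(=O)(=O)c2ccccc2)cc(OC)c1OC`: > 100000 nM
Compound 3 `COc1cc(-c2nccn2-c2ccc3cc[nH]c3c2)cc(OC)c1OC`: 1700 nM

In a functional assay on MDA-MB-468 cells (Homo sapiens) for antiproliferative activity, read by MTT assay, with a stated time of 72 h (a higher number here means a weaker inhibitor, a lower number a stronger inhibitor), compound 1 gives only a limit, > 100000 nM, and no number. Compound 2 likewise gives only a limit, > 100000 nM. Compound 3, which carries an aromatic group instead of the propyl, gives a measured value of 1700 nM. So compound 1 sits at the weak end of what is shown, where (the limit of > 100000 nM in this assay, at which 2 of the 3 values shown sit).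

The unmeasured compound 4 `COc1cc(-c2nccn2-c2ccc(F)cc2)cc(OC)c1OC` differs from compound 1 in a single way: 4-fluorophenyl in place of propyl on an aromatic nitrogen. Within the data shown here, compound 1 and compound 2 carry either a propyl or a non-aromatic group on that nitrogen, while the one with an aromatic group there, compound 3, is measured at 1700 nM. On that basis the step from compound 1 to compound 4 in this assay is expected to be large and toward stronger inhibition, an at least 20-fold lower number from compound 1 to compound 4 (1.30 log units; beyond the scatter), though less than what compound 3 shows. For compound 4 the expected value is 5000 nM, with a range from 800 nM to 50000 nM.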

Compound 4, half-maximal inhibitory concentration: 62200 nM
Beside the measured number, compound 4's estimate is 12-fold (1.09 log units) below it; the whole stated range lies below it.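

In this assay compound 4 gives 62200 nM as a measured value, so a 4-fluorophenyl on this aromatic nitrogen is a change that brings the reading inside the range the assay can count. Compound 1 gives > 100000 nM as a limit and not a number. Going by these compounds, the change can therefore be read only as an at least 1.6-fold lower number from compound 1 to compound 4 (0.20 log units; that floor lies within the scatter) and its true size stays unknown, because one end of the step is a limit: the limit of > 100000 nM in this assay, at which 2 of the 4 values shown sit.

Both compound 3 and compound 4 carry an aromatic group at this position, yet compound 3 gives 1700 nM and compound 4 a much weaker reading, so an aromatic ring alone does not settle the activity here. Still open, on these data alone, is how an amine or a carboxylic acid on that ring, or a longer chain in place of the propyl, would read.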